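Benzyloxy added to the core of compound 1

The source may hold more compounds than are shown below. What is called first, only, known or untested is meant among the compounds shown, and "the series" means these compounds.

Measured so far, in an assay on a cell-free system (plasma) for antagonist activity at proteinase-activated receptor 4 (Homo sapiens), with a stated time of 5 min, in the presence of a further agent that is not named here; a lower number here means a stronger inhibitor, a higher number a weaker inhibitor:
compound 1 `COc1nn2cc(-c3cc4ccccc4o3)nc2s1` gives 15000 nM
compound 2 `COc1cc(OCc2ccccc2OCc2ccccc2)c2cc(-c3cn4nc(OC)sc4n3)oc2c1` gives 2500 nM
compound 3 `COc1cc(OCc2cccc(COc3ccccc3)c2)c2cc(-c3cn4nc(OC)sc4n3)oc2c1` gives 600 nM

Compound 1 stands at the highest of the three numbers in this assay ; compound 2 lies nearest to it and compound 3 furthest, both differences beyond the scatter. Compound 4 `COc1nn2cc(-c3cc4ccc(OCc5ccccc5)cc4o3)nc2s1` differs from compound 1 in one place: benzyloxy in place of hydrogen on an aromatic carbon. Among the compounds with values here, no measured pair differs in exactly this way, so no measured step is available. Compound 2 and compound 3, which carry further substitution on the shared core, both give lower numbers in this assay than compound 1, so a downward step beyond the scatter is expected, estimated as a 3.8-fold lower number from compound 1 to compound 4 (0.57 log units; beyond the scatter). For compound 4 the expected value in this assay is 4000 nM, with a range from 1500 nM to 12000 nM.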

Compound 4, half-maximal inhibitory concentration: > 30000 nM
Compound 4: a limit, no number; the forecaster's own chance of this, stated with the estimate: 10%; middle value at least 7.5-fold (0.87 log units) from the limit.
By their numbers in this assay, from the lowest: compound 3; then compound 2; then compound 1. At a limit, above all of these: compound 4.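

In this assay compound 4 gives > 30000 nM, which is a limit of the assay and not a number. Benzyloxy in place of hydrogen on this aromatic carbon gives an at least 2.0-fold higher number from compound 1 to compound 4 (0.30 log units; that floor lies within the scatter), the first single-place step in the series, and it shows no gain in inhibition at this position. The true size of the step cannot be read, since only its floor is known.

Open, going by these compounds, is whether an amine or a carboxylic acid on this same carbon would give a lower number than hydrogen. Also open, on these data alone, is how benzyloxy behaves on the other carbons of this ring.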